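The source may hold more compounds than are shown below. What is called first, only, known or untested is meant among the compounds shown, and "the series" means these compounds.

Measured compounds:

Compound 1, `Cc1cc(O)cc(-c2nn(CC#N)cc2-c2ccnc(-c3ccc(Oc4ccccc4)cc3)c2)c1`: 94%
Compound 2, `COc1cc(C)cc(-c2nn(CC#N)cc2-c2ccnc(-c3ccc(N(C)C)cc3)c2)c1`: 89%

Of the compounds shown here, two have been tested in a functional assay on EKVX cells (Homo sapiens) for cytotoxicity, read by sulforhodamine B assay, with a stated time of 48 h, tested at 0.01 uM; a higher number here means a weaker effect of the compound at the concentration tested, a lower number a stronger effect. In this assay compound 1 gives 94%, and compound 2 gives 89%. The two numbers lie within the usual scatter of each other, so neither compound can be said to act more strongly than the other at this concentration; both leave most of the cells' growth untouched.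

The next compound, compound 3, `Cc1cc(O)cc(-c2nn(CC#N)cc2-c2ccnc(-c3ccc(N(C)C)cc3)c2)c1`, has not yet been measured. It differs from compound 2 in one place: hydrogen in place of methyl on an oxygen on an aromatic ring. Within the data shown here, no pair of measured compounds shows what such a change does in this assay, so the direction of the step is open. Since compound 2 gives 89%, near the top of the scale, the step from compound 2 to compound 3 is expected to stay within the scatter: a number 1 percentage points higher from compound 2 to compound 3 (within the scatter). Compound 3 is therefore estimated at 90%, within a range of 78% to 100%.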

Compound 3, a percentage reported as activity, at one concentration (the size of the read-out at that concentration, not a potency): 86%
For compound 3 the middle estimate is 4 percentage points above the measured one; the measured number falls inside the stated range.
By their numbers in this assay, from the lowest: compounds 3, 2 and 1 (each within the scatter of the next).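

In this assay, hydroxy in place of methoxy on the 3-methoxy-5-methylphenyl group gives a number 3 percentage points lower from compound 2 to compound 3 (within the scatter), so removing this methyl produces no change that can be told from the scatter. At the far end of the molecule, dimethylamino in place of phenoxy on an aromatic carbon gives a number 8 percentage points lower from compound 1 to compound 3 (within the scatter), which is also too small to read as a real effect at this single concentration. Nothing available explains why these numbers lie so close together.

The compounds shown leave open what a longer chain such as ethoxy on that oxygen, or an amine in place of the hydroxy, would do. They also leave open whether either step would become visible at a higher concentration.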